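From a Chloro to a 4-Cyanophenyl on the Amide

This account rests on a few compounds, and the source may have more. Where it says the series, first, only, none or still open, it means among the compounds named here.

Two measured compounds frame this step. Compound 1 `Cc1nc(-c2ccc(F)cc2)ccc1C(=O)Nc1ccc2ccn(C)c2c1` in an in vitro functional assay on 1321-N1 cells for antagonist activity at transient receptor potential cation channel subfamily V member 1 (Homo sapiens), read by FLIPR and calcium flux (a lower number here means a less potent compound, a higher number a more potent compound, by a factor of ten per unit of this negative logarithm), gives only a limit, < 6.5, which is the limit of < 6.5 in this assay, at which 1 of the 2 values shown sits. Compound 2 `O=C(Nc1ccc2cccnc2c1)c1ccc(Cl)nc1` likewise gives only a limit in this assay, < 6.7, which is the limit of < 6.7 in this assay, at which 1 of the 2 values shown sits. Going by the values given here, compound 2 therefore stands at a limit rather than at a number, and the one further value shown is a limit as well, so no measured step between these two compounds can be stated.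

Compound 3 `N#Cc1ccc(-c2ccc(C(=O)Nc3ccc4cccnc4c3)cn2)cc1` differs from compound 2 in one place: 4-cyanophenyl in place of chloro on an aromatic carbon. No measured step of this kind is available among the compounds shown, so the expected size rests on the change alone. Since both measured compounds sit at limits, a gain is expected but with wide uncertainty, and the step from compound 2 to compound 3 is estimated at a number at least 0.30 log units higher from compound 2 to compound 3 (that floor lies within the scatter). Compound 3 is expected to give about 7 in this assay, within 6 to 8.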

Compound 3, negative logarithm of the antagonist equilibrium constant: < 6.6
Compound 3: no number, only a limit; the forecaster's own chance of this, stated with the estimate: 40%; middle value at least 0.40 log units from the limit.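

Going by these compounds alone, compound 2 and compound 3 both give only limits in this assay, and no step between them can be read. The compounds shown leave open where either compound truly stands and whether 4-cyanophenyl in place of chloro changes potency at all.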